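The source may report more compounds than this note shows. Statements on the series, on what has been measured and on what is new or still open speak of the compounds shown alone.

Measured so far:
compound 1 `Clc1ccc(-c2ncnc3c2cnn3CCN2CCCCC2)cc1`: 43 nM
compound 2 `c1cc(-c2ncnc3c2cnn3CCN2CCCCC2)ccn1`: 1720 nM

Among the compounds with values here, in an assay on HEK293 cells for displacement of a labelled ligand from Sigma non-opioid intracellular receptor 1 (Homo sapiens), read by scintillation counting, with a stated time of 120 min (on this read-out lower numbers stand for stronger inhibition and higher numbers for weaker inhibition), compound 1 gives 43 nM, while compound 2 gives 1720 nM, the higher of the two numbers and thus the weaker binder; that gap, a 40-fold higher number from compound 1 to compound 2 (1.60 log units; beyond the scatter), is the only step seen. Compound 3 `Cn1cc(-c2ncnc3c2cnn3CCN2CCCCC2)cn1` differs from compound 2 by 1-methyl-1H-pyrazol-4-yl in place of pyridin-4-yl on an aromatic carbon. Within the data shown here, no measured step tests this swap, and the single known step, a 40-fold higher number from compound 1 to compound 2 (1.60 log units; beyond the scatter), concerns a different change, so it offers little guidance. For compound 3 a step of a 1.5-fold higher number from compound 2 to compound 3 (0.16 log units; within the scatter) is therefore expected, nothing beyond the scatter. The estimate for compound 3 is 2500 nM, within 700 nM to 9000 nM.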

Compound 3, inhibition constant: 9460 nM
Estimate against measurement, compound 3: 3.8-fold (0.58 log units) below, outside the stated range (above it).
By their numbers in this assay, from the lowest: compound 1; then compound 2; then compound 3.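

In this assay this position also responds to a swap between two heteroaromatic rings, not only to the loss of 4-chlorophenyl: the five-membered 1-methyl-1H-pyrazol-4-yl gives a 5.5-fold higher number from compound 2 to compound 3 (0.74 log units; beyond the scatter) and so binds more weakly than pyridin-4-yl. Measured against 4-chlorophenyl, the same group gives a 220-fold higher number from compound 1 to compound 3 (2.34 log units; beyond the scatter) and widens the gap already seen with compound 2. No available measurement explains either step.

Ring size, nitrogen count and the methyl all change together here, so their contributions cannot be separated. As far as these compounds go, it remains open how an unsubstituted phenyl, 4-fluorophenyl or a pyrazole lacking the methyl would compare.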